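The source may report more compounds than this note shows. Statements on the series, on what has been measured and on what is new or still open speak of the compounds shown alone.

Measured in a functional assay on PC-3 cells (Homo sapiens) for antiproliferative activity, read by sulforhodamine B assay, with a stated time of 48 h; a lower number here means a stronger inhibitor, a higher number a weaker inhibitor:

Compound 1 `C[C@H]1N=C2C[C@H]3C[C@H](C3(C)C)[C@@]2(C)OC1=O` — compound 1 gives 42000 nM
Compound 2 `CC1(C)[C@H]2CC[C@]1(C)[C@H]1OC(=O)CN=C21` — compound 2 gives 145000 nM
Compound 3 `CC(C)(C)OC(=O)NCCC[C@H]1N=C2C[C@H]3C[C@H](C3(C)C)[C@@]2(C)OC1=O` — compound 3 gives 60000 nM

Compound 1 has the lowest number of the three. Its gap to compound 3 lies within the scatter of repeated measurements, so the two cannot be set in order. Its gap to compound 2 lies beyond the scatter; compound 2 is a smaller bicyclic lactone without the fused cyclobutane unit, and nothing links the two by a single change, so only the two values themselves are noted.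

Compound 4 `CC1(C)[C@H]2CC3=N[C@H](CCC(=O)O)C(=O)O[C@]3(C)[C@@H]1C2` is not yet measured. It follows from compound 1 by carboxymethyl in place of hydrogen on a saturated chain carbon bound to a saturated ring carbon. Going by the values given here, compound 3 carries a longer protected amine chain at the same saturated chain carbon and stays within the scatter of compound 1, which is the only guide on substitution at this position. Among the compounds with values here, no measured step of this kind exists in this assay, so no direction beyond the scatter is expected; a small loss is taken as the more likely side. For compound 4 the step of a 1.3-fold higher number from compound 1 to compound 4 (0.12 log units; within the scatter) is expected. Compound 4 is estimated at 55000 nM in this assay, with a range from 20000 nM to 150000 nM.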

Compound 4, half-maximal inhibitory concentration: 38000 nM
Compound 4: the middle estimate sits 1.4-fold (0.16 log units) above what was measured; measured number inside the range.
By their numbers in this assay, from the lowest: compounds 4, 1 and 3 (each within the scatter of the next); then compound 2.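

In this assay, going by these compounds alone, carboxymethyl in place of hydrogen on a saturated chain carbon bound to a saturated ring carbon gives the first single-place step at this position (a 1.1-fold lower number from compound 1 to compound 4 (0.04 log units; within the scatter)), and it lies within the scatter. Read one bond further out, as methyl to 2-carboxyethyl, the same step shows that this position carries a free acid chain on the core of compound 1 with no change that the assay can resolve. Nothing measured bears on the reason for this flat result.

On these data alone, what a free amine on this chain, or a longer chain ending in a carboxylic acid, does in this assay stays open. Within the data shown here, also open is whether any group at this position moves the number beyond the scatter, since the one step read here does not.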